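Trimming the amine: cyclopropylamino to dimethylamino

The compounds below may be only part of what the source reports. "The series", "measured", "known", "first", "only" and "open" are said of these compounds alone.

Compound 1 `CC(C)(C)CNCc1ccc2c(c1)CCC[C@H]2NC(=O)C[C@@H]1CCCCN1S(=O)(=O)c1cccc(C(F)(F)F)c1` gives 230 nM in a functional assay for inhibition of B1 bradykinin receptor (Homo sapiens), read by calcium flux; a lower number here means a stronger inhibitor, a higher number a weaker inhibitor.
Compound 2 `O=C(C[C@@H]1CCCCN1S(=O)(=O)c1cccc(C(F)(F)F)c1)N[C@@H]1CCCc2cc(CNCC3CC3)ccc21` gives 31 nM in this assay.
Compound 3 `O=C(C[C@@H]1CCCCN1S(=O)(=O)c1cccc(C(F)(F)F)c1)N[C@@H]1CCCc2cc(CNC3CC3)ccc21` gives 47 nM in this assay.

Among these three, compound 3 holds the second highest number. Its nearest neighbour is compound 2, whose value lies within the scatter of it, so no order between the two can be drawn; compound 1 lies further off, beyond the scatter, and is the weakest inhibitor of the set.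

Compound 4 `CN(C)Cc1ccc2c(c1)CCC[C@H]2NC(=O)C[C@@H]1CCCCN1S(=O)(=O)c1cccc(C(F)(F)F)c1` differs from compound 3 in one place: dimethylamino in place of cyclopropylamino on a saturated chain carbon bound to an aromatic carbon. All three measured steps touch this same position. a 7.4-fold lower number from compound 1 to compound 2 (0.87 log units; beyond the scatter) and a 4.9-fold lower number from compound 1 to compound 3 (0.69 log units; beyond the scatter) show a modest gain when the neopentyl group gives way to a group holding a three-membered ring, while a 1.5-fold higher number from compound 2 to compound 3 (0.18 log units; within the scatter) shows that cyclopropyl and cyclopropylmethyl sit within the scatter of each other. Going by the values given here, the entering dimethylamino carries no hydrogen-bond donor, a feature no measured pair covers, so its direction is open. With the neopentyl case as the only marked shift, no step beyond the scatter is expected: a 1.3-fold higher number from compound 3 to compound 4 (0.11 log units; within the scatter). Compound 4 is therefore expected to give about 60 nM, within 20 nM to 180 nM.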

Compound 4, half-maximal inhibitory concentration: 160 nM
Compound 4: the middle estimate sits 2.7-fold (0.43 log units) below what was measured; the measured number falls inside the stated range.
By their numbers in this assay, from the lowest: compounds 2 and 3 (each within the scatter of the next); then compounds 4 and 1 (each within the scatter of the next).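

In this assay, the position on a saturated chain carbon bound to an aromatic carbon proves sensitive to a small change, with a 3.4-fold higher number from compound 3 to compound 4 (0.53 log units; beyond the scatter) and a 5.2-fold higher number from compound 2 to compound 4 (0.71 log units; beyond the scatter) both lying beyond the scatter, so dimethylamino does not sit level with the two groups holding a three-membered ring. The other comparison, a 1.4-fold lower number from compound 1 to compound 4 (0.16 log units; within the scatter) within the scatter, places dimethylamino level with neopentylamino, and the set now falls into two tiers: compounds 2 and 3 on the stronger side, compounds 1 and 4 on the weaker, where the earlier compounds had shown only neopentylamino standing apart. No measurement at hand accounts for this split.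

The step from compound 3 to compound 4 removes the three-membered ring and the hydrogen-bond donor together, so the compounds shown cannot say which of the two differences goes with the higher number. An ethylamino group, which keeps the donor without a ring, and a cyclopropyl(methyl)amino group, which keeps the ring without the donor, would pull these two differences apart at this position.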